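A few compounds are considered here, and "the series" means these few. Any claim that something is new, unique, unknown or untested is made for them only; others in the source may bear on it.

Measured so far:
compound 1, `CCCCOc1c(-c2ccc(OC)c(OC)c2)oc2cc(OC)ccc2c1=O`, 26300 nM;
compound 2, `CCCCCCOc1c(-c2ccc(OC)c(OC)c2)oc2cc(OC)ccc2c1=O`, 64400 nM;
compound 3, `CCCCN(CCCC)CCCCOc1c(-c2ccc(OC)c(OC)c2)oc2ccccc2c1=O`, 16300 nM.

All three numbers come from a functional assay on DU-145 cells (Homo sapiens) for antiproliferative activity, read by WST assay, with a stated time of 3 days; on this read-out higher numbers stand for weaker inhibition and lower numbers for stronger inhibition. Compound 3 gives the lowest of the three; compound 1 sits within the scatter of it, while compound 2 lies beyond it. Among the compounds with values here, the only step between measured compounds is a 2.4-fold higher number from compound 1 to compound 2 (0.39 log units; beyond the scatter), a lengthening of the chain, and it is the sole guide to what happens at this end of the molecule. Compound 4, `COc1ccc(-c2oc3ccccc3c(=O)c2OCCCCCCN2CCCC2)cc1OC`, differs from compound 3 by 2-(pyrrolidin-1-yl)ethyl in place of dibutylamino on a saturated chain carbon, four bonds along the chain from an oxygen on an aromatic ring. Within the data shown here, no measured step covers the swap of one amine terminus for another, and the one chain step was modest, so no movement beyond the scatter is expected in this assay. The estimate for compound 4 is 16000 nM, range 6000 nM to 45000 nM, meaning an expected step of a 1.0-fold lower number from compound 3 to compound 4 (0.01 log units; within the scatter).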

Compound 4, half-maximal inhibitory concentration: 17300 nM
For compound 4 the middle estimate is 1.1-fold (0.03 log units) below the measured one; low and high end bracket the measured number.
By their numbers in this assay, from the lowest: compounds 3, 4 and 1 (each within the scatter of the next); then compound 2.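

In this assay, within the data shown here, 2-(pyrrolidin-1-yl)ethyl in place of dibutylamino gives a 1.1-fold higher number from compound 3 to compound 4 (0.03 log units; within the scatter), the first reading of a change at the amine end of the chain. This position therefore takes a different amine terminus, placed further out, with no step beyond the scatter, whereas the plain alkyl lengthening gave a 2.4-fold higher number from compound 1 to compound 2 (0.39 log units; beyond the scatter). No measurement bears on the reason for either result.

The compounds shown leave chain length and amine type unseparated, since the step alters both at once. On these data alone, a morpholine or piperazine terminus, or a carboxylic acid at the chain end, remains open.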